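Replacing the chloro aryl group with a methoxy aryl group

The source may hold more compounds than are shown below. What is called first, only, known or untested is meant among the compounds shown, and "the series" means these compounds.

Compound 1 `COc1cc(C(=O)c2sc(-c3ccc(Cl)cc3)cc2N)cc(OC)c1OC` gives 70 nM in a functional assay on CCRF-CEM cells (Homo sapiens) for antiproliferative activity (on this read-out higher numbers stand for weaker inhibition and lower numbers for stronger inhibition), the second highest of the three numbers. Compound 2 `COc1cc(C(=O)c2sc(-c3ccc(C(F)(F)F)cc3)cc2N)cc(OC)c1OC` gives 270 nM, and compound 3 `COc1cc(C(=O)c2sc(-c3ccsc3)cc2N)cc(OC)c1OC` gives 9.6 nM. Compound 4 `COc1cccc(-c2cc(N)c(C(=O)c3cc(OC)c(OC)c(OC)c3)s2)c1` differs from compound 1 as follows: 3-methoxyphenyl in place of 4-chlorophenyl on an aromatic carbon. Among the compounds with values here, no measured step introduces a methoxy group, but both measured steps touch the same position: the change from compound 1 to compound 2 gave a 3.9-fold higher number from compound 1 to compound 2 (0.59 log units; beyond the scatter), and the change from compound 1 to compound 3 gave a 7.3-fold lower number from compound 1 to compound 3 (0.86 log units; beyond the scatter). Either direction is therefore possible, and a step within or just beyond the scatter is expected. Compound 4 is estimated at 110 nM, with a range of 30 nM to 450 nM, which means an expected step of a 1.6-fold higher number from compound 1 to compound 4 (0.20 log units; within the scatter).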

Compound 4, half-maximal inhibitory concentration: 16 nM
Compound 4: the middle estimate sits 6.9-fold (0.84 log units) above what was measured; the whole stated range lies above it.
By their numbers in this assay, from the lowest: compounds 3 and 4 (each within the scatter of the next); then compound 1; then compound 2.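

In this assay, within the data shown here, thiophen-3-yl was the only group at this position with a low number among the earlier compounds, but a substituted phenyl group can also give one: a 4.4-fold lower number from compound 1 to compound 4 (0.64 log units; beyond the scatter), and a 17-fold lower number from compound 2 to compound 4 (1.23 log units; beyond the scatter). Against thiophen-3-yl the change stays small, a 1.7-fold higher number from compound 3 to compound 4 (0.22 log units; within the scatter), so a six-membered aromatic ring does not in itself set compound 4 apart from compound 3. Nothing measured here accounts for these steps. The compounds shown leave open whether 4-methoxyphenyl would match 3-methoxyphenyl, and how a phenyl group carrying an amine or a carboxylic acid would compare.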